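The source may hold more compounds than are shown below. What is called first, only, known or untested is meant among the compounds shown, and "the series" means these compounds.

Going by the values given here, in a functional assay on Bel-7402 cells (Homo sapiens) for cytotoxicity, read by MTT assay, with a stated time of 72 h (a lower number here means a stronger inhibitor, a higher number a weaker inhibitor), compound 1 (`C=C1C(=O)[C@@]23C(=O)OC[C@]4(C(=O)CCC(C)(C)[C@H]4C=O)[C@@H]2CC[C@@H]1[C@H]3OC(=O)CC`) gives 1650 nM and stands lowest of the three compounds measured so far, with both others beyond the scatter from it. Compound 2 (`C=C1C(=O)[C@@]23C(=O)OC[C@]4(C(=O)CCC(C)(C)[C@H]4C=O)[C@@H]2CC[C@@H]1[C@H]3OC(=O)c1ccc(C(F)(F)F)cc1`) gives 3990 nM and compound 3 (`C=C1C(=O)[C@@]23C(=O)OC[C@]4(C(=O)CCC(C)(C)[C@H]4C=O)[C@@H]2CC[C@@H]1[C@H]3OC(=O)c1ccc(F)cc1`) gives 3750 nM in the same read-out, and the step of a 1.1-fold lower number from compound 2 to compound 3 (0.03 log units; within the scatter) lies within the scatter. Compound 4 (`C=C1C(=O)[C@@]23C(=O)OC[C@]4(C(=O)CCC(C)(C)[C@H]4C=O)[C@@H]2CC[C@@H]1[C@H]3OC(=O)c1ccccc1F`) is still unmeasured and, relative to compound 1, carries 2-fluorophenyl in place of ethyl on a carbonyl carbon. Among the compounds with values here, two measured steps bear on this change: 4-(trifluoromethyl)phenyl in place of ethyl gave a 2.4-fold higher number from compound 1 to compound 2 (0.38 log units; beyond the scatter) and 4-fluorophenyl in place of ethyl gave a 2.3-fold higher number from compound 1 to compound 3 (0.36 log units; beyond the scatter) as modest steps beyond the scatter. Neither compound carries the 2-fluorophenyl group, so the comparison is imperfect, but a similarly modest step towards a higher number is expected in this assay here. The expected change is a 2.1-fold higher number from compound 1 to compound 4 (0.33 log units; beyond the scatter) by this estimate. For compound 4 the estimate is 3500 nM within an expected range of 1700 nM to 7000 nM in this read-out.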

Compound 4, half-maximal inhibitory concentration: 3950 nM
Compound 4: the middle estimate sits 1.1-fold (0.05 log units) below what was measured, within the range that was stated.
By their numbers in this assay, from the lowest: compound 1; then compounds 3, 4 and 2 (each within the scatter of the next).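

In this assay, 2-fluorophenyl on this carbonyl carbon gives a 2.4-fold higher number from compound 1 to compound 4 (0.38 log units; beyond the scatter) as its step from ethyl, which makes it a third aromatic group on the same side of ethyl. The earlier compounds shown here carried only 4-substituted phenyl groups, whereas here the step of a 1.1-fold higher number from compound 3 to compound 4 (0.02 log units; within the scatter) for 2-fluorophenyl in place of 4-fluorophenyl and the step of a 1.0-fold lower number from compound 2 to compound 4 (0.00 log units; within the scatter) for 2-fluorophenyl in place of 4-(trifluoromethyl)phenyl leave these three groups indistinguishable in this read-out. Nothing available explains why the three aromatic groups differ from ethyl.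

From the compounds shown here alone, it remains open whether a longer chain such as butyl or a shorter one such as methyl would track ethyl. Going by these compounds, it is also open whether a phenyl ring carrying an amine or a carboxylic acid would stay with the three aromatic groups.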